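The compounds below may be only part of what the source reports. "The series", "measured", "known", "first", "only" and "open" are said of these compounds alone.

Compound 2 `O=C(C1CC1)N1CCN(Cc2nc3ccccc3n2Cc2ccccc2C(F)(F)F)CC1` gives the lowest number of the three measured compounds in an assay on isolated protein for inhibition of aldehyde dehydrogenase 1A1 (Homo sapiens), read by spectrophotometry, tested at 10 uM (on this read-out higher numbers stand for more inhibition at the one concentration tested (going by the name of the read-out) and lower numbers for less inhibition), where compound 2 gives 56.3%. Its nearest neighbour is compound 1 `Cc1cccc(Cn2c(CN3CCN(C(=O)C4CCCC4)CC3)nc3ccccc32)c1`, which in this assay gives 67.5%, and the furthest is compound 3 `CCC(=O)N1CCN(Cc2nc3ccccc3n2Cc2cccc(C)c2)CC1`, which in this assay gives 85.1%. Within the data shown here, the one step between measured compounds that differ in a single place, a number 17.6 percentage points higher from compound 1 to compound 3 (beyond the scatter), concerns the carbonyl substituent and not the benzyl group, so it does not bear directly on the present change.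

Compound 4 `O=C(C1CC1)N1CCN(Cc2nc3ccccc3n2Cc2cccc(F)c2)CC1` differs from compound 2 by 3-fluorophenyl in place of 2-(trifluoromethyl)phenyl on a saturated chain carbon bound to an aromatic nitrogen. Among the measured compounds shown here, no measured pair isolates this change; compounds 1 and 3 carry a 3-methylphenyl at the same place alongside different carbonyl groups, and both show higher inhibition than compound 2, but the two differences cannot be separated. An estimate for compound 4 is therefore only loosely anchored; a small rise, a number 9.7 percentage points higher from compound 2 to compound 4 (within the scatter), is expected. Compound 4 is estimated to give 66% in this assay, within a range from 48% to 84%.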

Compound 4, a percentage reported as inhibition, at one concentration (the size of the read-out at that concentration, not a potency): 27.2%
Compound 4: middle estimate off by 38.8 percentage points, on the high side; the measured number lies below the stated range.
By their numbers in this assay, from the lowest: compound 4; then compound 2; then compound 1; then compound 3.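

With the rest of the structure unchanged, 3-fluorophenyl in place of 2-(trifluoromethyl)phenyl on a saturated chain carbon bound to an aromatic nitrogen gives a number 29.1 percentage points lower from compound 2 to compound 4 (beyond the scatter) in this assay. This is the first pair shown that isolates a change at this place, and it establishes that the aromatic group here can alone move the inhibition beyond the scatter, in this case downward. No measurement at hand accounts for the fall.

On these data alone, what remains open is whether the loss comes from removing the 2-(trifluoromethyl)phenyl or from introducing the 3-fluorophenyl. An unsubstituted phenyl at this place, carrying the same carbonyl group as compound 4, would give the reference needed to read each group on its own.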